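Terminal Double Bond in the Butyl Chain

The source may hold more compounds than are shown below. What is called first, only, known or untested is meant among the compounds shown, and "the series" means these compounds.

Measured compounds:
compound 1 `COc1cc(Cc2nc3c(N)nc(F)nc3n2CC2CCC2)cc(OC)c1OC`: 40700 nM
compound 2 `CCCCn1c(Cc2cc(OC)c(OC)c(OC)c2)nc2c(N)nc(F)nc21`: 24000 nM

In a functional assay on MCF7 cells (Homo sapiens) for antiproliferative activity (on this read-out higher numbers stand for weaker inhibition and lower numbers for stronger inhibition), compound 2 gives 24000 nM, a number that is separated from compound 1 only within the scatter. Compound 3 `C=CCCn1c(Cc2cc(OC)c(OC)c(OC)c2)nc2c(N)nc(F)nc21` differs from compound 2 by vinyl in place of ethyl on a saturated chain carbon, two bonds along the chain from an aromatic nitrogen. Going by the values given here, the only measured step, a 1.7-fold lower number from compound 1 to compound 2 (0.23 log units; within the scatter), altered the chain on the same aromatic nitrogen and stayed within the scatter, and no measured step tests a double bond at all. No shift beyond the scatter is therefore expected, which the estimated step of no change at the digits printed from compound 2 to compound 3 (within the scatter) reflects. Compound 3 is expected to give about 24000 nM, within 10000 nM to 55000 nM.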

Compound 3, half-maximal inhibitory concentration: 33100 nM
For compound 3 the middle estimate is 1.4-fold (0.14 log units) below the measured one; low and high end bracket the measured number.
By their numbers in this assay, from the lowest: compounds 2, 3 and 1 (each within the scatter of the next).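

In this assay, vinyl in place of ethyl on the butyl chain gives a 1.4-fold higher number from compound 2 to compound 3 (0.14 log units; within the scatter) and so shows that a terminal double bond at this position brings no shift beyond the scatter. Allyl in place of cyclobutyl gives a 1.2-fold lower number from compound 1 to compound 3 (0.09 log units; within the scatter) and so adds a third chain on this aromatic nitrogen that cannot be told apart from the other two. No evidence beyond these numbers bears on the result.

Still open, from the compounds shown here alone, is whether a longer chain, or a chain ending in an amine or a carboxylic acid, would move the number beyond the scatter.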